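Aryl swap from compound 3 to compound 4

A few compounds are considered here, and "the series" means these few. Any claim that something is new, unique, unknown or untested is made for them only; others in the source may bear on it.

In a functional assay on HeLa cells (Homo sapiens) for inhibition, with a stated time of 72 h (a lower number here means that less compound is needed, a higher number that more compound is needed for the effect), compound 1 `COc1cc(CNCc2ccncc2)ccc1OCc1ccc(F)cc1` gives 6400 nM and compound 2 `COc1cc(CNCc2ccncc2)ccc1OCc1ccc(Cl)cc1` gives 890 nM while compound 3 `COc1cc(CNCc2ccncc2)ccc1OCc1cnc(Cl)c(Cl)c1` gives 220 nM as the lowest of the three numbers. The change to compound 4 `COc1cc(CNCc2ccncc2)ccc1OCc1ccc(Cl)cc1Cl` is 2,4-dichlorophenyl in place of 5,6-dichloropyridin-3-yl on a saturated chain carbon bound to an oxygen on an aromatic ring and reads 2,4-dichlorophenyl in place of 5,6-dichloropyridin-3-yl on a saturated chain carbon bound to an oxygen on an aromatic ring. Two modest steps bear on it: chloro in place of fluoro gave a 7.2-fold lower number from compound 1 to compound 2 (0.86 log units; beyond the scatter) and 5,6-dichloropyridin-3-yl in place of 4-chlorophenyl gave a 4.0-fold lower number from compound 2 to compound 3 (0.61 log units; beyond the scatter) on the same carbon. For the measured compounds named here, no measured pair separates the ring nitrogen from the chlorine pattern. A small rise in this assay is therefore expected, possibly within the scatter. The expected step is a 1.6-fold higher number from compound 3 to compound 4 (0.20 log units; within the scatter) in this estimate. Compound 4 is estimated at 350 nM with a range from 110 nM to 1000 nM as the expected span.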

Compound 4, half-maximal effective concentration: 3900 nM
The estimate for compound 4 lay 11-fold (1.05 log units) below the measured number, outside the stated range (above it).
By their numbers in this assay, from the lowest: compound 3; then compound 2; then compounds 4 and 1 (each within the scatter of the next).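

In this assay, a dichloro ring on this saturated chain carbon does not by itself hold the low number of compound 3: 2,4-dichlorophenyl in place of 5,6-dichloropyridin-3-yl gives an 18-fold higher number from compound 3 to compound 4 (1.25 log units; beyond the scatter) with the same count of heavy atoms. Adding chlorine to the 4-chlorophenyl ring does not help either, giving a 4.4-fold higher number from compound 2 to compound 4 (0.64 log units; beyond the scatter), while the step to 4-fluorophenyl reads a 1.6-fold lower number from compound 1 to compound 4 (0.22 log units; within the scatter), so the effect of halogen here depends on the ring and its pattern. No measurement at hand offers a reason for these steps.

The ring nitrogen and the chlorine pattern remain unseparated. A pyridinyl group without chlorine, or a phenyl ring bearing a nitrile, lies outside the compounds shown.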